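Permeability notes: from compound 2 to compound 3

The source may hold more compounds than are shown below. What is called first, only, known or untested is meant among the compounds shown, and "the series" means these compounds.

Measured so far:
Compound 1 `Fc1ccc(Cc2ccc3c(NCCCNCc4ccco4)ccnc3c2)c(Cl)c1` in an ADME assay for permeability, using PAMPA, with a stated time of 30 min, at pH 7.4 (on this read-out lower numbers stand for lower permeability and higher numbers for higher permeability), gives 23 10^-6 cm/s.
Compound 2 `c1coc(CNCCCNc2ccnc3cc(CC4CCCCC4)ccc23)c1` in this assay gives 23 10^-6 cm/s.

Compound 2 stands level with compound 1 on the numbers shown; its nearest neighbour is compound 1, and the single measured step, no change at the digits printed from compound 1 to compound 2 (within the scatter), falls within the scatter. Among the measured compounds shown here, that step puts cyclohexyl in place of 2-chloro-4-fluorophenyl on a saturated chain carbon bound to an aromatic carbon, so the series so far has seen a saturated ring traded for an aromatic one at that chain position without any shift in this assay.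

Compound 3 `c1coc(CNCCCNc2ccnc3cc(-c4cccc5ccccc45)ccc23)c1` is not yet measured. It differs from compound 2 by naphthalen-1-yl in place of cyclohexylmethyl on an aromatic carbon. For the measured compounds named here, no measured step touches an aromatic carbon directly in this way, so the one step at hand bears on it only by analogy: a ring swap of comparable bulk left the read-out unchanged. On that basis the expected step in this assay is none beyond the scatter, a 1.0-fold lower number from compound 2 to compound 3 (0.02 log units; within the scatter). The value for compound 3 is estimated at 22 10^-6 cm/s, with a range from 11 10^-6 cm/s to 40 10^-6 cm/s.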

Compound 3, apparent permeability in the ADME assay: 237 10^-6 cm/s
For compound 3 the middle estimate is 11-fold (1.03 log units) below the measured one; measured number above the stated range.
By their numbers in the ADME assay, from the lowest: compounds 1 and 2 (each within the scatter of the next); then compound 3.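

In the ADME assay this position turns out to be far from indifferent: after no change at the digits printed from compound 1 to compound 2 (within the scatter), the change to naphthalen-1-yl gives a 10-fold higher number from compound 2 to compound 3 (1.01 log units; beyond the scatter) and a 10-fold higher number from compound 1 to compound 3 (1.01 log units; beyond the scatter). The two large steps share the entering naphthalen-1-yl on the aromatic carbon, whereas exchanging the ring within the two groups that keep a chain carbon left the read-out level. In a physicochemical assay for acid dissociation, compound 2 gives 9.47 and compound 3 gives 9.47, which is no change at the digits printed from compound 2 to compound 3 (within the scatter), and no measurement at hand accounts for the large step in the ADME assay.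

Naphthalen-1-yl differs from cyclohexylmethyl and from 2-chloro-4-fluorobenzyl both in its ring system and in having no chain carbon, so the compounds shown leave open which of these two differences carries the step. A phenyl group on the same aromatic carbon, or a naphthalen-1-ylmethyl group there, would pull the two apart.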